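Fluoro in place of chloro: compound 2 to compound 4

The source may hold more compounds than are shown below. What is called first, only, known or untested is meant among the compounds shown, and "the series" means these compounds.

In a physicochemical assay for lipophilicity (a higher number here means a more lipophilic compound, a lower number a more polar compound), compound 1 `Fc1ccccc1C1=NC(c2ccccc2)CO1` gives 3.51, compound 3 `Clc1ccccc1C1=NC(c2ccccc2)CO1` gives 3.56 and compound 2 `Fc1cccc(Cl)c1C1=NC(c2ccccc2)CO1` gives 3.45, so compound 2 stands within the scatter of both others. Compound 4 `Fc1cccc(F)c1C1=NC(c2ccccc2)CO1` differs from compound 2 by fluoro in place of chloro on an aromatic carbon, ortho to a large group and meta to a fluoro group. The nearest measured evidence is the reverse exchange, chloro in place of fluoro, which gave a number 0.05 log units higher from compound 1 to compound 3 (within the scatter). Chloro in place of hydrogen gave a number 0.06 log units lower from compound 1 to compound 2 (within the scatter), and hydrogen in place of fluoro gave a number 0.11 log units higher from compound 2 to compound 3 (within the scatter). With all three steps this small, no step beyond the scatter is expected in this assay. The expected change is a number 0.07 log units lower from compound 2 to compound 4 (within the scatter). For compound 4 the estimated value is 3.38, with an expected range from 3.15 to 3.6.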

Compound 4, partition coefficient: 3.01
The estimate for compound 4 lay 0.37 log units above the measured number; measured number below the stated range.
By their numbers in this assay, from the lowest: compound 4; then compounds 2, 1 and 3 (each within the scatter of the next).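

In this assay the position ortho to a large group and meta to a fluoro group responds to fluoro: fluoro in place of chloro gives a number 0.44 log units lower from compound 2 to compound 4 (beyond the scatter) and fluoro in place of hydrogen gives a number 0.50 log units lower from compound 1 to compound 4 (beyond the scatter) on the same carbon. Chloro in place of hydrogen there did not separate the compounds (a number 0.06 log units lower from compound 1 to compound 2 (within the scatter)), so the series responds to fluoro at this position but not to chloro. Nothing on hand bears on why this fluoro step differs. Open, from the compounds shown here alone, is how a methoxy group or an amine at this position would read, and whether the step from fluoro persists when the other phenyl ring carries a substituent.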